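Adding a Methoxy Group: Expected Outcome for Compound 4

A few compounds are considered here, and "the series" means these few. Any claim that something is new, unique, unknown or untested is made for them only; others in the source may bear on it.

Measured so far:
In an ADME assay on RAW264.7 cells (Mus musculus) for cytotoxicity, read by MTT assay, with a stated time of 24 h, tested at 2.5 ug/mL (on this read-out higher numbers stand for a weaker effect at the one concentration tested and lower numbers for a stronger effect), compound 1 `COc1ccc(/C=C/C(=O)c2ccc(OC)c(OC)c2)cc1` gives 93.1%.
Compound 2 `COc1ccc(/C=C/C(=O)c2ccc(OC)c(OC)c2)cc1OC` gives 91.9%.
Compound 3 `COc1ccc(C(=O)CCc2ccc(OC)c(OC)c2)c(O)c1` gives 89%.

Compound 2 differs from compound 1 by one change, (methoxy in place of hydrogen on an aromatic carbon), and this made a step of a number 1.2 percentage points lower from compound 1 to compound 2 (within the scatter). The three numbers lie close together, so none of the three compounds can be called stronger or weaker than another on this read-out.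

Compound 4 `COc1ccc(C(=O)CCc2ccc(OC)c(OC)c2OC)c(O)c1` has not been measured. It arises from compound 3 by methoxy in place of hydrogen on an aromatic carbon. How the core of compound 3 differs from the core of compound 1 is not broken down here. The change from compound 3 to compound 4 is the same kind of change as that from compound 1 to compound 2, but the surroundings differ: in compound 4 the methoxy enters ortho to a large group, ortho to a methoxy group and meta to a methoxy group, whereas in compound 2 it entered ortho to a methoxy group and meta to a large group.

For compound 4 a step of a number 1 percentage points lower from compound 3 to compound 4 (within the scatter) is expected, resting on the step of a number 1.2 percentage points lower from compound 1 to compound 2 (within the scatter) seen for the same kind of change. Compound 4 is therefore estimated at 88%, with a range from 78% to 96%.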

Compound 4, a percentage reported as activity, at one concentration (the size of the read-out at that concentration, not a potency): 94.4%
Compound 4: the middle estimate sits 6.4 percentage points below what was measured, within the range that was stated.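

In this assay, methoxy in place of hydrogen on an aromatic carbon gave a number 5.4 percentage points higher from compound 3 to compound 4 (within the scatter). Set beside the earlier step on the other core, this step does not differ from it by more than repeated measurements would: the same change on two cores in this assay, a number 1.2 percentage points lower (within the scatter) from compound 1 to compound 2 and a number 5.4 percentage points higher (within the scatter) from compound 3 to compound 4, 6.6 percentage points apart, within the scatter of two such steps. So on both cores the change stays within the scatter, and nothing here shows that the core alters what this change does; equally, two small steps at a single concentration do not prove that the change acts the same way on both cores, nor that it would on a third.

The compounds shown leave open whether a different group in the same place, such as an amine, a carboxylic acid or a longer chain like ethoxy, would move the number beyond the scatter. They also leave open whether any of these compounds would separate from the others at a higher concentration, where a stronger effect might appear.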